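A Methyl Moved from Ring Nitrogen to Ring Carbon

This account rests on a few compounds, and the source may have more. Where it says the series, first, only, none or still open, it means among the compounds named here.

Within the data shown here, compound 1 `CO/N=C/c1c(N)ncnc1Oc1ccc2[nH]ccc2c1` was tested in a functional assay on HeLa cells (Homo sapiens) for antiproliferative activity (a lower number here means a stronger inhibitor, a higher number a weaker inhibitor), and gave 1870 nM, the highest of the two numbers measured so far. Among the measured compounds shown here, its nearest neighbour is compound 2 `CO/N=C/c1c(N)ncnc1Oc1ccc2c(ccn2C)c1`, which in this assay gave 375 nM; the step of a 5.0-fold lower number from compound 1 to compound 2 (0.70 log units; beyond the scatter) is the only change measured to date. Compound 3 `CO/N=C/c1c(N)ncnc1Oc1ccc2[nH]c(C)cc2c1` has not yet been tested. It differs from compound 1 by methyl in place of hydrogen on an aromatic carbon. For the measured compounds named here, the only measured step that bears on this change is a 5.0-fold lower number from compound 1 to compound 2 (0.70 log units; beyond the scatter), and it is a loose guide, since that methyl sat on the ring nitrogen rather than on a carbon of the same five-membered ring. A shift in the same direction but smaller than that step is expected, namely a 1.9-fold lower number from compound 1 to compound 3 (0.27 log units; within the scatter). The estimate for compound 3 in this assay is therefore 1000 nM, with a range from 300 nM to 3500 nM.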

Compound 3, half-maximal inhibitory concentration: 388 nM
Estimate against measurement, compound 3: 2.6-fold (0.41 log units) above, within the range that was stated.
By their numbers in this assay, from the lowest: compounds 2 and 3 (each within the scatter of the next); then compound 1.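

In this assay, a methyl on the aromatic carbon next to the ring nitrogen gives a 4.8-fold lower number from compound 1 to compound 3 (0.68 log units; beyond the scatter), which shows that this carbon, as well as the ring nitrogen, responds to a single added methyl. Beside a 5.0-fold lower number from compound 1 to compound 2 (0.70 log units; beyond the scatter), this step runs the same way and is of much the same size, yet compound 3 keeps the hydrogen on the ring nitrogen, so a lower number here does not depend on replacing that hydrogen. Nothing available explains why either methyl lowers the number.

From the compounds shown here alone, it remains open whether a longer chain such as ethyl, or an amine or a carboxylic acid, would be tolerated on this carbon. The compounds shown also leave open what methyl groups on both the ring nitrogen and this carbon would do together.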